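Swapping an ortho group on a phenoxy imidazoline

The source may report more compounds than this note shows. Statements on the series, on what has been measured and on what is new or still open speak of the compounds shown alone.

Compound 1 `C=C(C)c1ccccc1OC(C)C1=NCCN1` is the starting point. In a functional assay on CHO cells for agonist activity at Alpha-2C adrenergic receptor (Homo sapiens) (on this read-out lower numbers stand for an effect already at smaller amounts and higher numbers for an effect only at larger amounts of compound), compound 1 gives 115 nM. Going by the values given here, its only measured neighbour is compound 2 `CC(C)Oc1ccccc1OC(C)C1=NCCN1`, which in this assay gives 100 nM. Among the compounds with values here, the one step measured so far, a 1.2-fold lower number from compound 1 to compound 2 (0.06 log units; within the scatter), shows that exchanging these two groups on the aromatic carbon makes no difference the assay can resolve. On the two numbers shown, compound 1 has the higher one, but the gap to compound 2 lies within the scatter, so the two stand level.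

Compound 3 `CC(Oc1ccccc1S(C)(=O)=O)C1=NCCN1` is not yet measured. It differs from compound 1 as follows: methylsulfonyl in place of 1-methylethenyl on an aromatic carbon. The measured step from compound 1 to compound 2 touches the same aromatic carbon, but the group that enters there is a different one, so it bears only loosely on this change, and it was itself within the scatter. With so little to go on, a moderate step toward larger amounts is expected for compound 3, a 3.5-fold higher number from compound 1 to compound 3 (0.54 log units; beyond the scatter). The estimate for compound 3 in this assay is therefore 400 nM, with a range from 80 nM to 2000 nM.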

Compound 3, half-maximal effective concentration: 316 nM
Compound 3: the middle estimate sits 1.3-fold (0.10 log units) above what was measured; the range from low to high includes it.
By their numbers in this assay, from the lowest: compounds 2 and 1 (each within the scatter of the next); then compound 3.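

Where exchanging 1-methylethenyl for isopropoxy left the number level, placing methylsulfonyl on the same aromatic carbon gives a 2.7-fold higher number from compound 1 to compound 3 (0.44 log units; beyond the scatter) in this assay, so the group at this position can shift the result by more than the scatter. Set against isopropoxy, methylsulfonyl gives a 3.2-fold higher number from compound 2 to compound 3 (0.50 log units; beyond the scatter). Both steps are modest, and the change raises the concentration needed without removing the effect: compound 3 still gives 316 nM in this read-out. Nothing available here explains what about methylsulfonyl accounts for this rise.

Going by these compounds alone, with only three groups compared at this aromatic carbon, it remains open whether the higher number is particular to methylsulfonyl or would also appear with related groups, such as a sulfonamide or a nitrile. Also open, going by these compounds, is how an amine or a longer alkyl chain would behave at the same place, and whether any group there could bring the number below the level shared by compound 1 and compound 2.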